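Bromo in place of acetyl: notes on the next step

The compounds below may be only part of what the source reports. "The series", "measured", "known", "first", "only" and "open" are said of these compounds alone.

In an ADME assay on a cell-free system (plasma, Homo sapiens) for metabolic stability, read by HPLC (on this read-out higher numbers stand for a longer-lived compound and lower numbers for a shorter-lived compound), compound 1 `CN(/N=N/c1ccc(C(N)=O)cc1)C(=O)CCc1ccc(O)cc1` gives 48.5 h and compound 2 `CC(=O)c1ccc(/N=N/N(C)C(=O)CCCCc2ccc(O)cc2)cc1` gives 32.7 h on the same read-out. Compound 2 thus stands level with compound 1, the two values lying within the scatter of each other. Compound 3 `CN(/N=N/c1ccc(Br)cc1)C(=O)CCCCc1ccc(O)cc1` puts bromo in place of acetyl on an aromatic carbon para to a large group, counted as bromo in place of acetyl on an aromatic carbon with the rest of compound 2 unchanged. Among the compounds with values here, no measured pair isolates a change at this place, so the data give no size for such a step. The expectation rests on compound 2 at 32.7 h as the only anchor, and no shift beyond the scatter is expected in this assay for this swap. The expected change is a 1.1-fold lower number from compound 2 to compound 3 (0.04 log units; within the scatter) and lies within the scatter. For compound 3 the estimated half-life is 30 h with 14 h to 60 h as the expected range.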

Compound 3, half-life in the plasma assay: 162 h
For compound 3 the middle estimate is 5.4-fold (0.73 log units) below the measured one, and the stated range ends below it.
By their numbers in the plasma assay, from the lowest: compounds 2 and 1 (each within the scatter of the next); then compound 3.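

Within the data shown here, in the plasma assay the aromatic carbon para to a large group proves sensitive to what sits on it: bromo in place of acetyl gives a 5.0-fold higher number from compound 2 to compound 3 (0.69 log units; beyond the scatter) and is the first step that isolates a change at one place. In a physicochemical assay, read by HPLC, in phosphate buffer, with a stated time of 8 days, at pH 7.4 (on this read-out higher numbers stand for a more stable compound and lower numbers for a less stable compound), the same swap gives no change at the digits printed from compound 2 to compound 3 (within the scatter). In the physicochemical assay compound 2 holds 100% and compound 3 holds 100% in buffer, so the two compounds separate only in the plasma assay on these data. Nothing at hand accounts for the size of this step, which rests on a single pair.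

As far as these compounds go, whether chloro, methoxy or a carboxylic acid on the same aromatic carbon would move the half-life as bromo does remains open. Among these compounds, it is equally open whether the step would hold with a shorter chain in place of the one shared by compound 2 and compound 3.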